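The compounds below may be only part of what the source reports. "The series", "measured", "known", "first", "only" and "open" are said of these compounds alone.

Compound 1 `CC(NC(=O)c1ccc(C(=N)N)cc1)C(C)(C)C(=O)N1CCC(CC(=O)O)CC1`: 0.883 h
Compound 2 `CC(C)(C(=O)N1CCC(CC(=O)O)CC1)C(NC(=O)c1ccc(C(=N)N)cc1)c1ccc(Cl)cc1`: 1.2 h

In an in vivo ADME assay on the whole organism (Cavia porcellus) (a higher number here means that the compound lasts longer, a lower number that the compound disappears faster), compound 1 gives 0.883 h and has only compound 2 for comparison, which lies within the scatter of it. Compound 3 `CC(NC(=O)c1ccc(C(=N)N)cc1F)C(C)(C)C(=O)N1CCC(CC(=O)O)CC1` carries one change from compound 1, (fluoro in place of hydrogen on an aromatic carbon), namely fluoro in place of hydrogen on an aromatic carbon. Among the measured compounds shown here, the single measured step, a 1.4-fold higher number from compound 1 to compound 2 (0.13 log units; within the scatter), replaces methyl with 4-chlorophenyl at a different place, so it bears only loosely on this change. No step beyond the scatter is therefore expected in this assay. The expected step is a 1.1-fold higher number from compound 1 to compound 3 (0.03 log units; within the scatter). For compound 3 the estimate is 0.95 h, with an expected range from 0.5 h to 1.8 h.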

Compound 3, half-life: 1.4 h
The estimate for compound 3 lay 1.5-fold (0.17 log units) below the measured number; measured number inside the range.
By their numbers in this assay, from the lowest: compounds 1, 2 and 3 (each within the scatter of the next).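

In this assay the step with fluoro in place of hydrogen on an aromatic carbon, ortho to a large group, is a 1.6-fold higher number from compound 1 to compound 3 (0.20 log units; within the scatter) and so stays within the usual scatter. Among the compounds shown here, this is the first reading of a change on the aromatic ring, since the earlier pair differed only on the chain. No supporting measurement bears on why the half-life behaves this way.

As far as these compounds go, whether chloro, methoxy or an amine at this place would give a step beyond the scatter remains open. Also open, from the compounds shown here alone, is whether fluoro would behave the same alongside the 4-chlorophenyl group of compound 2.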